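From ethynyl to 2-chloroethyl on a carbonyl carbon

The source may hold more compounds than are shown below. What is called first, only, known or untested is meant among the compounds shown, and "the series" means these compounds.

Measured in a functional assay on HCT-116 cells (Homo sapiens) for inhibition, read by MTT assay, with a stated time of 48 h (a lower number here means a stronger inhibitor, a higher number a weaker inhibitor), so far:
Compound 1 `COc1cc(NCc2ccc(Cl)cc2)cc(OC)c1OC` gives > 80000 nM as a limit of the assay, not a number
Compound 2 `C/C=C/C(=O)N(Cc1ccc(OC)c(OC)c1)c1cc(OC)c(OC)c(OC)c1` gives 32800 nM
Compound 3 `C#CC(=O)N(Cc1ccc(OC)c(O)c1)c1cc(OC)c(OC)c(OC)c1` gives 310 nM

Among these three, only compound 2 and compound 3 have true numbers. Compound 3 has the lower one, and the gap to compound 2, its nearest neighbour, lies well beyond the usual scatter in this assay. A lower number means a stronger inhibitor, so compound 3 is the natural reference point for the next comparison.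

The next compound, compound 4 `COc1ccc(CN(C(=O)CCCl)c2cc(OC)c(OC)c(OC)c2)cc1O`, keeps the structure of compound 3 except for one group, with 2-chloroethyl in place of ethynyl on a carbonyl carbon. Among the measured compounds shown here, no two measured compounds differ in only one place, so this series offers no direct measure of what such a swap does. For the measured compounds named here, the expectation therefore rests on compound 3 , whose 310 nM is the lowest number so far, and on the loss of its ethynyl group. A weakening is expected, with an estimated step of a 6.5-fold higher number from compound 3 to compound 4 (0.81 log units; beyond the scatter) that would lie beyond the scatter. For compound 4 the estimated value is 2000 nM, with an expected range from 350 nM to 12000 nM in this assay.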

Compound 4, half-maximal inhibitory concentration: 150 nM
The estimate for compound 4 lay 13-fold (1.12 log units) above the measured number; measured number below the stated range.
By their numbers in this assay, from the lowest: compound 4; then compound 3; then compound 2. At a limit, above all of these: compound 1.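

Among the compounds shown here, this is the first pair that differs in one place only, so a change on this carbonyl carbon can now be read directly in this assay, where 2-chloroethyl in place of ethynyl gives a 2.1-fold lower number from compound 3 to compound 4 (0.32 log units; beyond the scatter). The step is modest, but it shows that the triple bond of the ethynyl group is not needed for activity in these cells: a 2-chloroethyl group, which has no triple bond, does slightly better on the same carbonyl carbon with the rest of the molecule unchanged. Nothing measured here explains why the swap runs in this direction.

The compounds shown leave open whether the gain belongs to the chlorine atom or simply to the two-carbon chain, a question that a plain ethyl group on the same carbonyl carbon would help to settle. They also leave open how much room this position allows, which a longer chain such as 3-chloropropyl or a 2-aminoethyl group in the same place would begin to test.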